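The source may hold more compounds than are shown below. What is called first, only, known or untested is meant among the compounds shown, and "the series" means these compounds.

Measured so far in a physicochemical assay for lipophilicity; a higher number here means a more lipophilic compound, a lower number a more polar compound:
compound 1, `Cc1ccc(/C=C2\CCC/C(=C\c3ccc([N+](=O)[O-])cc3)C2=O)cc1`, gives 5.08
compound 2, `Cc1ccc(/C=C2\CCC/C(=C\c3cccc([N+](=O)[O-])c3)C2=O)cc1`, gives 5.06
compound 3, `O=C1/C(=C/c2ccc(Cl)cc2)CCC/C1=C\c1ccc([N+](=O)[O-])cc1`, gives 5.08

Compound 2 stands within the scatter of both compound 1 and compound 3; the three numbers do not separate from one another in this assay. Among the compounds with values here, the one single-point step among the measured compounds, chloro in place of methyl on an aromatic carbon, reads no change at the digits printed from compound 1 to compound 3 (within the scatter).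

The next compound, compound 4, `O=C1/C(=C/c2ccc(F)cc2)CCC/C1=C\c1cccc([N+](=O)[O-])c1`, differs from compound 2 by fluoro in place of methyl on an aromatic carbon.

Within the data shown here, no measured step covers fluoro in place of methyl. The nearest guide is the exchange of methyl for chloro, which gave no change at the digits printed from compound 1 to compound 3 (within the scatter), so a halogen in place of methyl at this position has so far left this assay unchanged. On that basis compound 4 is expected to stay close to compound 2, with at most a small shift, if any, estimated as a number 0.16 log units lower from compound 2 to compound 4 (within the scatter) in this assay. Compound 4 is therefore expected at about 4.9, in the range 4.6 to 5.2, in this assay.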

Compound 4, partition coefficient: 5.06
Compound 4: middle estimate off by 0.16 log units, on the low side; the measured number falls inside the stated range.
By their numbers in this assay, from the lowest: compounds 2, 4, 1 and 3 (each within the scatter of the next).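

Within the data shown here, until now the only exchange read at this position was chloro in place of methyl, on the core of compound 1; fluoro in place of methyl, on the core of compound 2, now reads no change at the digits printed from compound 2 to compound 4 (within the scatter) in this assay. The 4-methylphenyl to 4-fluorophenyl exchange therefore joins the chloro exchange, and in both single-point pairs, compound 1 with compound 3 and compound 2 with compound 4, a halogen in place of methyl on this aromatic carbon leaves the number within the scatter, with neither pair going against that reading. Nothing measured here speaks to why the number holds through this exchange.

The compounds shown leave open whether a group of another kind on this aromatic carbon, such as an amine, a carboxylic acid or a longer chain, would also stay with compound 2 at 5.06 in this assay, since methyl, chloro and fluoro are the only groups seen there. All four compounds also carry the nitro group and the shared core, so the effect of replacing the nitro group with, for example, a nitrile remains unread.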